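Methylamino to ethylamino on two antiproliferative scaffolds

The source may report more compounds than this note shows. Statements on the series, on what has been measured and on what is new or still open speak of the compounds shown alone.

Measured compounds:
Compound 1, `CNCC(=O)Nc1cc(OC)ccc1C(=O)c1ccc(OC)c2c1OC(C)(C)C=C2`: 820 nM
Compound 2, `CCNCC(=O)Nc1cc(OC)ccc1C(=O)c1ccc(OC)c2c1OC(C)(C)C=C2`: 5200 nM
Compound 3, `C=C(c1cc(OC)c(OC)c(OC)c1)c1ccc(OC)cc1NC(=O)CNC`: 240 nM

All three were tested in a functional assay on MCF7 cells (Homo sapiens) for antiproliferative activity, read by MTT assay, with a stated time of 48 h; on this read-out lower numbers stand for stronger inhibition and higher numbers for weaker inhibition. Compound 1 gives 820 nM in this assay, and compound 2 gives 5200 nM. The two differ by one change, (methyl in place of hydrogen on a saturated chain carbon bound to an amine nitrogen), which produced a 6.3-fold higher number from compound 1 to compound 2 (0.80 log units; beyond the scatter).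

Compound 3 carries a different core; the difference between the core of compound 1 and the core of compound 3 is not broken down here. In this assay compound 3 gives 240 nM, the lowest of the three numbers, with its gap to compound 1 and to compound 2 both beyond the scatter.

Compound 4, `C=C(c1cc(OC)c(OC)c(OC)c1)c1ccc(OC)cc1NC(=O)CNCC`, has not yet been measured. It differs from compound 3 by methyl in place of hydrogen on a saturated chain carbon bound to an amine nitrogen, the same change seen between compound 1 and compound 2, at the same place. Within the data shown here, the one earlier instance gave a 6.3-fold higher number from compound 1 to compound 2 (0.80 log units; beyond the scatter). The two cores are not broken down here, so it is not known whether the change carries over unchanged, but with a single precedent the expectation rests on it. Compound 4 is therefore expected to show a step of about a 5.8-fold higher number from compound 3 to compound 4 (0.77 log units; beyond the scatter) in this assay, a weakening of the same kind as the earlier one. Compound 4 is estimated at 1400 nM, with a range from 500 nM to 4000 nM allowing for the different core.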

Compound 4, half-maximal inhibitory concentration: 860 nM
The estimate for compound 4 lay 1.6-fold (0.21 log units) above the measured number; low and high end bracket the measured number.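

In this assay, replacing methylamino with ethylamino on the second core again weakened the read-out, giving a 3.6-fold higher number from compound 3 to compound 4 (0.55 log units; beyond the scatter), so the direction of the change seen on the core of compound 1 held on the core of compound 3. Set side by side, the two steps cannot be separated in size: the same change on two cores in this assay, a 6.3-fold higher number (0.80 log units; beyond the scatter) from compound 1 to compound 2 and a 3.6-fold higher number (0.55 log units; beyond the scatter) from compound 3 to compound 4, 1.8-fold (0.25 log units) apart, within the scatter of two such steps Within this series the change therefore carried over from one core to the other in both direction and size, as far as the scatter allows, but this rests on a single pair of cores and does not show that it would hold on any further core, nor does it say why the added methyl weakens the read-out.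

The compounds shown leave open how the read-out would respond on either core to a longer chain such as propylamino, to a branched isopropylamino group, or to a plain primary amine or a dimethylamino group in place of methylamino. Among these compounds, they also leave open whether the weakening grows steadily with chain length or is confined to the single step from methylamino to ethylamino.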